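Ethyl in place of 4-chlorophenyl: a drop is expected

The source may report more compounds than this note shows. Statements on the series, on what has been measured and on what is new or still open speak of the compounds shown alone.

Compound 1, `NC(N)=NC(=O)c1nc(Cl)c(NCc2ccccc2Cl)nc1N`: 31%
Compound 2, `C=CCNc1nc(N)c(C(=O)N=C(N)N)nc1Cl`: 16%
Compound 3, `NC(N)=NC(=O)c1nc(Cl)c(NCc2ccc(Cl)cc2)nc1N`: 46%

All three were measured in an assay for inhibition of acid-sensing ion channel 3 (Homo sapiens), read by patch clamp, tested at 1 uM; on this read-out higher numbers stand for more inhibition at the one concentration tested (going by the name of the read-out) and lower numbers for less inhibition. Compound 3 stands highest of the three: the nearest number is that of compound 1, with a step of a number 15 percentage points higher from compound 1 to compound 3 (beyond the scatter), and the furthest is that of compound 2, with a step of a number 30 percentage points higher from compound 2 to compound 3 (beyond the scatter), both beyond the scatter.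

Compound 4, `CCCNc1nc(N)c(C(=O)N=C(N)N)nc1Cl`, has not yet been measured. It differs from compound 3 in one place: ethyl in place of 4-chlorophenyl on a saturated chain carbon bound to a nitrogen on an aromatic ring.

Within the data shown here, two measured steps bear on this change, since both swap a chlorophenyl for a small chain on the same carbon. The step of a number 15 percentage points lower from compound 1 to compound 2 (beyond the scatter) was a modest fall, and the step of a number 30 percentage points higher from compound 2 to compound 3 (beyond the scatter) was a modest rise, so replacing the ring by a short chain has twice gone with a lower number. Compound 4 is therefore expected to sit well below compound 3, with an estimated step of a number 28 percentage points lower from compound 3 to compound 4 (beyond the scatter). The estimate for compound 4 in this assay is 18%, within a range from 5% to 32%.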

Compound 4, a percentage reported as inhibition, at one concentration (the size of the read-out at that concentration, not a potency): 24%
Compound 4: middle estimate off by 6 percentage points, on the low side; the range from low to high includes it.
By their numbers in this assay, from the lowest: compounds 2, 4 and 1 (each within the scatter of the next, the first and the last beyond it); then compound 3.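

Compound 4 shows that the drop on leaving 4-chlorophenyl does not need the vinyl of compound 2: in this assay a saturated ethyl at this place gives a number 22 percentage points lower from compound 3 to compound 4 (beyond the scatter) and so stands clear of compound 3. Ethyl and vinyl cannot be told apart here, as the step of a number 8 percentage points higher from compound 2 to compound 4 (within the scatter) shows, and neither can ethyl and 2-chlorophenyl, as the step of a number 7 percentage points lower from compound 1 to compound 4 (within the scatter) shows, so a chlorophenyl in itself does not separate a compound from compound 4, and among these four only the 4-chlorophenyl of compound 3 does, though compound 1 and compound 2 still lie beyond the scatter of each other. Nothing available explains why the 4-chlorophenyl group stands apart from the others.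

The compounds shown leave open whether a longer chain, a phenyl without chlorine, or an amine or a carboxylic acid at the end of the chain would stay with compound 4 or approach compound 3. They also leave open how these differences would look at other concentrations, since this assay gives a single-concentration reading and not a potency.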